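Compound 1 and its methoxy-shifted isomer, compound 4

The source may hold more compounds than are shown below. What is called first, only, known or untested is meant among the compounds shown, and "the series" means these compounds.

compound 1 `COc1ccc(C2=NN(c3ccccc3Cl)C(c3cccc(Cl)c3)C2)cc1` – 7200 nM
compound 2 `COc1ccc(C2=NN(c3cccc(Cl)c3)C(c3cccc(Cl)c3)C2)cc1` – "not determined" (no result reported)
compound 3 `COc1ccc(C2=NN(c3ccccc3Cl)C(c3ccccc3Cl)C2)cc1` – "not determined" (no result reported)

Within the data shown here, in a functional assay on NCI-H1299 cells (Homo sapiens) for cytotoxicity, read by a luciferase reporter and CellTiter-Glo, with a stated time of 72 h (a higher number here means a weaker inhibitor, a lower number a stronger inhibitor), compound 1 gives 7200 nM as the only number available, so it cannot be ranked against compound 2 or compound 3. Compound 4 (`COc1ccccc1C1=NN(c2ccccc2Cl)C(c2cccc(Cl)c2)C1`) has yet to be measured. It carries 2-methoxyphenyl in place of 4-methoxyphenyl on a carbon with a double bond to nitrogen and is otherwise the same as compound 1. Among the measured compounds shown here, no measured step shows what such a change does. In this assay the estimated 1.1-fold higher number from compound 1 to compound 4 (0.05 log units; within the scatter) is therefore expected to stay within the usual scatter of repeated measurements, in neither direction. The estimated value for compound 4 is 8000 nM (expected range 3000 nM to 20000 nM).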

Compound 4, half-maximal inhibitory concentration: 13400 nM
The estimate for compound 4 lay 1.7-fold (0.22 log units) below the measured number, and the stated range covers the measured number.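

In this assay, among these compounds, the first measured step at this position, a 1.9-fold higher number from compound 1 to compound 4 (0.27 log units; within the scatter) on exchanging 4-methoxyphenyl for 2-methoxyphenyl, lies within the scatter. On this one pair, compound 1 and compound 4 cannot be told apart, so the placement of the methoxy group on this ring has no readable effect here. Nothing available offers a reason for this result. As far as these compounds go, whether an amine or a carboxylic acid on this ring would behave the same stays open. From the compounds shown here alone, with no numbers for compound 2 and compound 3, the role of the chlorine placements also stays open.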